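The compounds below may be only part of what the source reports. "The series", "measured", "known", "first", "only" and "open" are said of these compounds alone.

Measured compounds in an ADME assay on microsomes from liver (Homo sapiens) for metabolic stability, read by LC-MS; a lower number here means that the compound disappears faster, a higher number that the compound lasts longer:

Compound 1, `Cc1nc(C)c(C(=O)Nc2ccc(F)c(-c3nc4ncc(-c5cccnc5Cl)cn4n3)c2)o1`: compound 1 gives > 1.5 h, which is a limit of the assay and not a number.
Compound 2, `O=C(Nc1ccc(F)c(-c2nc3ncc(-c4cccc(F)c4)cc3[nH]2)c1)N1CCCC1`: compound 2 gives 0.185 h.
Compound 3, `O=C(Nc1ccc(F)c(-c2nc3ncc(-c4ccccc4F)cc3[nH]2)c1)N1CCCC1`: compound 3 gives 0.285 h.

Among the two numbers, compound 3 stands highest, and its nearest neighbour is compound 2: the step of a 1.5-fold higher number from compound 2 to compound 3 (0.19 log units; within the scatter) lies within the scatter, so the two values cannot be told apart. Compound 1 contributes only (the limit of > 1.5 h in this assay, at which 1 of the 3 values shown sits), which sets no number against which compound 3 can be placed.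

Compound 4, `O=C(Nc1ccc(F)c(-c2nc3ncc(-c4cc(F)cc(F)c4)cc3[nH]2)c1)N1CCCC1`, has not yet been measured in this assay. It differs from compound 3 in one place: 3,5-difluorophenyl in place of 2-fluorophenyl on an aromatic carbon. Among the compounds with values here, the only measured step that touches the same phenyl group, a 1.5-fold higher number from compound 2 to compound 3 (0.19 log units; within the scatter), moved a single fluorine between two positions and stayed within the scatter. Within the data shown here, that step speaks to a change of fluorine placement on this ring, but not to the entry of a second fluorine, for which no measured pair exists. Among the measured compounds shown here, with that single, flat step as the only guide, the expected step from compound 3 to compound 4 is a 1.1-fold lower number from compound 3 to compound 4 (0.06 log units; within the scatter), meaning no change beyond the scatter. Compound 4 is therefore estimated at 0.25 h in this assay, expected to fall between 0.12 h and 0.55 h.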

Compound 4, half-life: 0.175 h
The estimate for compound 4 lay 1.4-fold (0.15 log units) above the measured number; the measured number falls inside the stated range.
By their numbers in this assay, from the lowest: compounds 4, 2 and 3 (each within the scatter of the next). At a limit, above all of these: compound 1.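

Adding a second fluorine to the phenyl group gives, in this assay, a 1.1-fold lower number from compound 2 to compound 4 (0.02 log units; within the scatter) and so leaves the half-life unchanged within the scatter, the first measured pair to address the entry of a further fluorine on this ring. Replacing 2-fluorophenyl with 3,5-difluorophenyl gives a 1.6-fold lower number from compound 3 to compound 4 (0.21 log units; within the scatter) and is likewise no measurable change, even though both the number of fluorines and their placement differ. Taken together with the earlier step between the two monofluorinated compounds, all three pairs among compound 2, compound 3 and compound 4 lie within the scatter, so at this aromatic carbon of the six-membered aromatic ring with 1 nitrogen, these fluorine patterns cannot be told apart in this assay, and nothing measured here accounts for that flat result.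

The compounds shown leave open whether a substituent of another kind on this phenyl group, such as an amine, a carboxylic acid or a methoxy group, would move the half-life beyond the scatter. They also leave open whether removing every fluorine from this ring, leaving an unsubstituted phenyl, would change the half-life at all.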